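The source may report more compounds than this note shows. Statements on the series, on what has been measured and on what is new or still open speak of the compounds shown alone.

Measured compounds:
- compound 1 `CCCS(=O)(=O)c1cccc(C#Cc2cc(Cl)ccc2OCC(=O)O)c1`: 9 nM
- compound 2 `CCCS(=O)(=O)c1cc(C#Cc2cc(Cl)ccc2OCC(=O)O)c(C)cc1NC(C)=O`: 1.3 nM
- compound 3 `CCCS(=O)(=O)c1ccc(F)c(C#Cc2cc(Cl)ccc2OCC(=O)O)c1`: 3.4 nM

All three share a core in which an aryl acetylene carries the chloro-substituted aryloxyacetic acid; they differ only on the outer aromatic ring. In an assay on CHO cells for displacement of a labelled ligand from prostaglandin D2 receptor 2 (Homo sapiens), read by scintillation counting (a lower number here means a stronger inhibitor, a higher number a weaker inhibitor), compound 1 gives 9 nM and holds the highest number of the three. Its nearest neighbour is compound 3, where a 2.6-fold lower number from compound 1 to compound 3 (0.42 log units; beyond the scatter). Compound 2, which adds a methyl and an acetamido group to the same ring, sits further off, with compound 2 giving 1.3 nM in this assay.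

The next compound is compound 4 `O=C(O)COc1ccc(Cl)cc1C#Cc1cccc(C(F)(F)F)c1`. Relative to compound 1 the change is trifluoromethyl in place of propylsulfonyl on an aromatic carbon. Within the data shown here, no measured step touches this group: both of the measured steps leave the propylsulfonyl in place and add or alter substituents elsewhere on that ring. Among the measured compounds shown here, the only step with a single change, from compound 1 to compound 3, was modest and in the direction of a lower number, but it gives no guidance on removing the propylsulfonyl itself. Without a direct precedent, the expectation for compound 4 in this assay is a step toward a higher number, a 3.3-fold higher number from compound 1 to compound 4 (0.52 log units; beyond the scatter), with wide uncertainty. Compound 4 is therefore estimated at 30 nM, in a range from 8 nM to 120 nM.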

Compound 4, inhibition constant: 92 nM
The estimate for compound 4 lay 3.1-fold (0.49 log units) below the measured number, and the stated range covers the measured number.
By their numbers in this assay, from the lowest: compound 2; then compound 3; then compound 1; then compound 4.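

In this assay, among these compounds, the swap of propylsulfonyl for trifluoromethyl gives a 10-fold higher number from compound 1 to compound 4 (1.01 log units; beyond the scatter), the first measured change to the propylsulfonyl itself, and it shows that this place on the outer ring is far from indifferent to what it carries. The step is larger than the fluoro step on the same ring, a 2.6-fold lower number from compound 1 to compound 3 (0.42 log units; beyond the scatter), and runs the other way, so the shared core and the acid of compound 4 do not by themselves hold the number at the level of compound 1. The swap lowers the heavy-atom count and removes both hydrogen-bond acceptors of the leaving group in one move, and nothing measured here bears on which of these differences, if either, accounts for the higher number.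

The compounds shown leave open whether the sulfonyl or the propyl chain matters more, a question that a methylsulfonyl, a sulfonamide or a nitrile on this aromatic carbon would help to separate. They also leave open whether the fluoro, or the methyl and acetamido groups of compound 2, would lower the number with trifluoromethyl in place.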